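A few compounds are considered here, and "the series" means these few. Any claim that something is new, unique, unknown or untested is made for them only; others in the source may bear on it.

Measured compounds:
Compound 1, `CCCS(=O)(=O)Nc1ccc(F)c(C(=O)c2n[nH]c3ncc(-c4ccccc4)cc23)c1F` — in an assay for binding affinity to dual specificity mitogen-activated protein kinase kinase 4 (Homo sapiens), read by KINOMEscan, tested at 100 nM (on this read-out lower numbers stand for a stronger effect and higher numbers for a weaker effect at the one concentration tested), compound 1 gives 2.4%.
Compound 2, `CCCS(=O)(=O)Nc1ccc(F)c(C(=O)c2n[nH]c3ncc(-c4ccccc4C)cc23)c1F` — in this assay compound 2 gives 7%.

On these two numbers compound 2 stands highest; its nearest neighbour is compound 1, and the step of a number 4.6 percentage points higher from compound 1 to compound 2 (within the scatter) lies within the scatter, so the two cannot be set in order. Compound 3, `CCCS(=O)(=O)Nc1ccc(F)c(C(=O)c2n[nH]c3ncc(-c4cccc(C)c4)cc23)c1F`, has not yet been measured. It differs from compound 2 by 3-methylphenyl in place of 2-methylphenyl on an aromatic carbon. For the measured compounds named here, the only measured step concerns methyl in place of hydrogen on an aromatic carbon, not one methylphenyl in place of another, so it bears only loosely on the new change; it was a number 4.6 percentage points higher from compound 1 to compound 2 (within the scatter), within the scatter. Nothing in the two measured compounds points to a shift, so for compound 3 no step beyond the scatter is expected in this assay in either direction. Compound 3 is estimated at 6%, with a range from 1% to 20%. The step of a number 1 percentage points lower from compound 2 to compound 3 (within the scatter) implied by this estimate is expected to stay within the scatter.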

Compound 3, a percentage reported as activity, at one concentration (the size of the read-out at that concentration, not a potency): 15%
The estimate for compound 3 lay 9 percentage points below the measured number; measured number inside the range.
By their numbers in this assay, from the lowest: compounds 1, 2 and 3 (each within the scatter of the next, the first and the last beyond it).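

Set against each other, 2-methylphenyl and 3-methylphenyl cannot be placed in order in this assay: the step is a number 8 percentage points higher from compound 2 to compound 3 (within the scatter). Set against the unsubstituted phenyl, however, 3-methylphenyl gives a number 12.6 percentage points higher from compound 1 to compound 3 (beyond the scatter), the first step in the series beyond the scatter and a weaker effect at the one concentration tested, although still a modest one, while the corresponding step for 2-methylphenyl, a number 4.6 percentage points higher from compound 1 to compound 2 (within the scatter), stays within it. Nothing available accounts for the two methyl compounds falling on different sides of the scatter relative to compound 1.

From the compounds shown here alone, it remains open whether an ethyl, a methoxy, an amine or a carboxylic acid on this phenyl would go the way of the methyl in compound 3. These read-outs speak only of a stronger or weaker effect at the one concentration tested.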